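Sulfamoyl for nitro on a fused pyrazole core

The compounds below may be only part of what the source reports. "The series", "measured", "known", "first", "only" and "open" are said of these compounds alone.

Compound 1, `CSc1nn(-c2ccc([N+](=O)[O-])cc2)c2nc(Nc3ccccc3)n(-c3ccccc3)c(=O)c12`, is the starting point of this set. In a functional assay on the whole organism (strain Wistar albino) for inhibition, with Rattus norvegicus as the target, read by paw edema, with a stated time of 2 h, at a dose of 25 mg/kg by the oral route (a higher number here means more inhibition at the dose given (going by the name of the read-out), a lower number less inhibition), compound 1 gives 37.7%. Compound 2, `CSc1nn(-c2ccc(S(N)(=O)=O)cc2)c2nc(Nc3ccccc3)n(-c3ccccc3)c(=O)c12`, differs from it by one change, (sulfamoyl in place of nitro on an aromatic carbon), and in this assay compound 2 gives 54.1%, so that a number 16.4 percentage points higher from compound 1 to compound 2 (beyond the scatter).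

Compound 3, `O=c1c2c(Nc3ccc(Cl)cc3)nn(-c3ccc([N+](=O)[O-])cc3)c2nc(Nc2ccccc2)n1-c1ccccc1`, carries a different core, and the difference from compound 1 is (4-chlorophenyl)amino in place of methylsulfanyl on an aromatic carbon. In this assay compound 3 gives 39%, and a number 1.3 percentage points higher from compound 1 to compound 3 (within the scatter), so the two cores are not told apart by the measurements made so far.

Compound 4, `NS(=O)(=O)c1ccc(-n2nc(Nc3ccc(Cl)cc3)c3c(=O)n(-c4ccccc4)c(Nc4ccccc4)nc32)cc1`, has not yet been measured. It stands to compound 3 as compound 2 stands to compound 1: the change is sulfamoyl in place of nitro on an aromatic carbon. The surroundings of the change are described in the same words for both pairs, so this is the same change made on the other core.

Among the compounds with values here, the expectation for compound 4 rests on the one measured instance of this change, a number 16.4 percentage points higher from compound 1 to compound 2 (beyond the scatter), taken together with the fact that the two cores gave numbers within the scatter of each other, and the step is expected to be a number 16 percentage points higher from compound 3 to compound 4 (beyond the scatter). On that basis compound 4 is estimated to give 55% in this assay. The range in which compound 4 is expected to fall runs from 44% to 66%.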

Compound 4, a percentage reported as inhibition, in the whole organism at one dose (the size of the read-out at that dose, not a potency): 56.3%
Estimate against measurement, compound 4: 1.3 percentage points below; the measured number falls inside the stated range.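

In this assay, sulfamoyl in place of nitro gives a number 17.3 percentage points higher from compound 3 to compound 4 (beyond the scatter), and this step on the second core matches the one on the first: the same change on two cores in this assay, a number 16.4 percentage points higher (beyond the scatter) from compound 1 to compound 2 and a number 17.3 percentage points higher (beyond the scatter) from compound 3 to compound 4, 0.9 percentage points apart, within the scatter of two such steps. With sulfamoyl present, (4-chlorophenyl)amino in place of methylsulfanyl gives a number 2.2 percentage points higher from compound 2 to compound 4 (within the scatter), so the two cores remain unseparated with either group on the aromatic ring: the same change on two cores in this assay, a number 1.3 percentage points higher (within the scatter) from compound 1 to compound 3 and a number 2.2 percentage points higher (within the scatter) from compound 2 to compound 4, 0.9 percentage points apart, within the scatter of two such steps. Within this series, the sulfamoyl change therefore carried over between these two cores, but the agreement rests on just two pairs at a single dose and a single time, and it shows neither that the change would hold on a further core nor why it raises the number.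

The compounds shown carry only nitro or sulfamoyl at this place, para to a large group, so what an amine, a carboxylic acid or a methylsulfonyl group would give there remains open. They also hold only methylsulfanyl or (4-chlorophenyl)amino at the other varied place, and they leave open how the sulfamoyl step would behave with a longer chain or a morpholine there, or at other doses and times.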